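The compounds below may be only part of what the source reports. "The series", "measured", "known", "first", "only" and "open" are said of these compounds alone.

Working notes on the series. In a functional assay on MDA-MB-436 cells (Homo sapiens) for antiproliferative activity, read by MTT assay, with a stated time of 24 h (a lower number here means a stronger inhibitor, a higher number a weaker inhibitor), compound 1 `O=C(O)CC(NS(=O)(=O)c1cc(F)cc(F)c1)c1ccccc1` gives 69400 nM and compound 2 `CC(C)(C)c1ccc(C(CC(=O)O)NC(=O)c2ccc(C(F)(F)F)cc2)cc1` gives 82300 nM. For the measured compounds named here, these two values lie within the scatter of each other, so compound 1 stands level with the only other measured compound. Compound 3 `O=C(O)CC(NS(=O)(=O)c1cc(F)cc(F)c1)c1ccc(Cl)cc1Cl` differs from compound 1 as follows: 2,4-dichlorophenyl in place of phenyl on a saturated chain carbon bound to a saturated chain carbon and a sulfonamide nitrogen, with 2,4-dichlorophenyl in place of phenyl on a saturated chain carbon bound to a saturated chain carbon and a sulfonamide nitrogen. Going by the values given here, no measured step covers this change, so only a small move towards a lower number in this assay is expected, hardly beyond the scatter. The expected step is a 1.5-fold lower number from compound 1 to compound 3 (0.19 log units; within the scatter). Compound 3 is estimated at 45000 nM, within an expected range of 18000 nM to 100000 nM.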

Compound 3, half-maximal inhibitory concentration: 49600 nM
Beside the measured number, compound 3's estimate is 1.1-fold (0.04 log units) below it; the range from low to high includes it.
By their numbers in this assay, from the lowest: compounds 3, 1 and 2 (each within the scatter of the next).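

Putting 2,4-dichlorophenyl in place of phenyl on a saturated chain carbon bound to a saturated chain carbon and a sulfonamide nitrogen gives a 1.4-fold lower number from compound 1 to compound 3 (0.15 log units; within the scatter) in this assay, the first step read at this position. The two chlorine atoms are thus tolerated here, with no step beyond the scatter. For the compounds shown here, no measurement on these compounds bears on this result.

From the compounds shown here alone, whether a methoxy group or an amine on this ring would give a step beyond the scatter remains open. So does the effect of a pyridine ring in place of the phenyl.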